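Swapping a Bromophenyl Ring for Pyrimidine in Weak Antiproliferatives

The source may hold more compounds than are shown below. What is called first, only, known or untested is meant among the compounds shown, and "the series" means these compounds.

Compound 1, `CSc1ccccc1NC(=S)N1CCc2c(sc(NC(=O)c3ccccc3Cl)c2C(N)=O)C1`: 14600 nM
Compound 2, `NC(=O)c1c(NC(=O)c2ccccc2Br)sc2c1CCN(C(=S)Nc1ccccc1Cl)C2`: 14600 nM

Both compounds were tested in a functional assay on HL-60 cells (Homo sapiens) for antiproliferative activity, with a stated time of 24 h; a higher number here means a weaker inhibitor, a lower number a stronger inhibitor. Compound 1 gives 14600 nM, and compound 2 gives 14600 nM. The two values are level at the digits recorded, so compound 2 stands alongside compound 1 with nothing between them beyond the usual scatter. Both are weak inhibitors in this assay.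

Compound 3, `NC(=O)c1c(NC(=O)c2ccncn2)sc2c1CCN(C(=S)Nc1ccccc1Cl)C2`, has not yet been measured. It differs from compound 2 in one place: pyrimidin-4-yl in place of 2-bromophenyl on a carbonyl carbon. The new group sits on a carbonyl carbon whose other neighbour is an amide-type nitrogen. Going by the values given here, no measured pair of compounds shows this same difference, so any expectation rests only on the two weak, level values already in hand. The estimate therefore implies a step of a 1.2-fold higher number from compound 2 to compound 3 (0.09 log units; within the scatter), expected to stay within the scatter or at most to weaken the compound slightly. On that basis compound 3 is expected to give about 18000 nM in this assay, with a range from 6000 nM to 50000 nM.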

Compound 3, half-maximal inhibitory concentration: 34600 nM
Beside the measured number, compound 3's estimate is 1.9-fold (0.28 log units) below it; the range from low to high includes it.
By their numbers in this assay, from the lowest: compounds 1 and 2 (each within the scatter of the next); then compound 3.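

Going by these compounds alone, replacing 2-bromophenyl with pyrimidin-4-yl on the carbonyl carbon gives a 2.4-fold higher number from compound 2 to compound 3 (0.37 log units; beyond the scatter) in this assay, the first single change in this small set whose size can be read, and it lies beyond the usual scatter. The step is modest and runs towards a weaker inhibitor, so at this position the ring with two nitrogens and two hydrogen-bond acceptors does not improve on the carbon-only ring that carries bromine. No supporting data are available to explain the shift.

The swap removes the bromine and adds the ring nitrogens together, and the compounds shown do not separate these two parts of the change. An unsubstituted phenyl ring would show what the loss of bromine alone does at this carbonyl carbon, while a pyridin-4-yl ring, with a single ring nitrogen, would help show whether one nitrogen is enough to produce a step of this size.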